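Swapping an amine side group at two ring positions

The compounds below may be only part of what the source reports. "The series", "measured", "known", "first", "only" and "open" are said of these compounds alone.

Compound 1 `CN(CCCN1CCCCC1)c1cccc(C(=O)N2CCc3ccc(OS(N)(=O)=O)cc3C2)c1` and compound 3 `CN(CCCN1CCCCC1)c1ccc(C(=O)N2CCc3ccc(OS(N)(=O)=O)cc3C2)cc1` share the same atoms joined differently; how their cores differ is not broken down here. In an assay on HEK293 cells for inhibition of Steryl-sulfatase (Homo sapiens), tested at 1 uM (a higher number here means a stronger effect of the compound at the concentration tested, a lower number a weaker effect), compound 1 gives 30.6% and compound 3 gives 40.7%. Compound 2 `CCN(Cc1cccc(Br)c1)c1cccc(C(=O)N2CCc3ccc(OS(N)(=O)=O)cc3C2)c1` gives 24.9% in this assay. The change from compound 1 to compound 2 is (3-bromobenzyl)(ethyl)amino in place of methyl(3-(piperidin-1-yl)propyl)amino on an aromatic carbon, and it gave a number 5.7 percentage points lower from compound 1 to compound 2 (within the scatter). Compound 4 `CCN(Cc1cccc(Br)c1)c1ccc(C(=O)N2CCc3ccc(OS(N)(=O)=O)cc3C2)cc1` carries the same kind of change, ((3-bromobenzyl)(ethyl)amino in place of methyl(3-(piperidin-1-yl)propyl)amino on an aromatic carbon), placed para rather than meta to a large group. For compound 4 a small step is expected, a number 5.7 percentage points lower from compound 3 to compound 4 (within the scatter), because a number 5.7 percentage points lower from compound 1 to compound 2 (within the scatter) stayed within the scatter. Compound 4 is therefore estimated at 35% in this assay, likely between 22% and 48%.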

Compound 4, a percentage reported as inhibition, at one concentration (the size of the read-out at that concentration, not a potency) in the Steryl-sulfatase assay: 97.2%
The estimate for compound 4 lay 62.2 percentage points below the measured number; measured number outside the range, above it.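

In the Steryl-sulfatase assay compound 3 gives 40.7% and compound 4 gives 97.2%. In the Steryl-sulfatase assay the same swap acted differently on the two cores, and on the core of compound 4 it gave a number 56.5 percentage points higher from compound 3 to compound 4 (beyond the scatter). Its effect cannot simply be carried from one core to the other in this series: the same change on two cores in the Steryl-sulfatase assay, a number 5.7 percentage points lower (within the scatter) from compound 1 to compound 2 and a number 56.5 percentage points higher (beyond the scatter) from compound 3 to compound 4, 62.2 percentage points apart, beyond the scatter of two such steps. In a physicochemical assay for lipophilicity (on this read-out higher numbers stand for higher lipophilicity and lower numbers for lower lipophilicity), compound 3 gives 1.93 and compound 4 gives 1.93. In the physicochemical assay the swap gave no change at the digits printed from compound 3 to compound 4 (within the scatter), so that read-out does not separate the two compounds. With one pair on each core, these results do not show why the cores differ or how other amine side groups would behave.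

As far as these compounds go, it remains open whether the rise seen with compound 4 depends on the bromine, the benzyl ring or the ethyl group. A plain benzyl group in place of the 3-bromobenzyl group, or a methyl group in place of the ethyl group, on the core of compound 4 would help separate these parts.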